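A nitrogen-linked ring replaces an oxygen-linked one

The source may report more compounds than this note shows. Statements on the series, on what has been measured and on what is new or still open speak of the compounds shown alone.

Of the compounds shown here, three built on a shared core have been measured in an assay on cells for displacement of a labelled ligand from metabotropic glutamate receptor 2 (Homo sapiens), read by scintillation counting, with a stated time of 60 min; on this read-out lower numbers stand for stronger inhibition and higher numbers for weaker inhibition. Compound 1 `COc1ccc(COc2ccc(-c3ccn4c(CC5CC5)nnc4c3C(F)(F)F)cc2F)cn1` gives 11.8 nM in this assay. Compound 2 `Clc1cc(-c2ccn3c(CC4CC4)nnc3c2Cl)ccc1OC1CCOCC1` gives 22.9 nM, the highest of the three numbers, although compound 1 lies within the usual scatter of it. Among the measured compounds shown here, compound 3 `FC(F)(F)c1c(-c2ccc(OC3CCOCC3)c(Cl)c2)ccn2c(CC3CC3)nnc12` gives 5.25 nM, and the only step that changes one group at a time is a 4.4-fold lower number from compound 2 to compound 3 (0.64 log units; beyond the scatter).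

Compound 4 `O[C@H]1CC[C@H](Nc2ccc(-c3ccn4c(CC5CC5)nnc4c3Cl)cc2Cl)CC1` is compound 2 with one change: (4-hydroxycyclohexyl)amino in place of (oxan-4-yl)oxy on an aromatic carbon. For the measured compounds named here, no measured step bears on this kind of change. Going by the values given here, the single known step concerns a trifluoromethyl group in place of a chloro group on another ring, and compound 1 differs from compound 2 in more than one place, so only its value can be compared. With nothing to anchor a direction, the expected outcome for compound 4 is a step of a 1.2-fold higher number from compound 2 to compound 4 (0.09 log units; within the scatter), that is, no shift beyond the scatter, though with a wide margin. The estimate for compound 4 in this assay is therefore 28 nM, with a range from 7 nM to 120 nM.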

Compound 4, inhibition constant: 3.02 nM
For compound 4 the middle estimate is 9.3-fold (0.97 log units) above the measured one; measured number below the stated range.
By their numbers in this assay, from the lowest: compounds 4 and 3 (each within the scatter of the next); then compounds 1 and 2 (each within the scatter of the next).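

Among the compounds shown here, the earlier compounds said nothing about this position, since their one step lies on another ring. In this assay, the swap gives a 7.6-fold lower number from compound 2 to compound 4 (0.88 log units; beyond the scatter), so the number does respond to the group on this aromatic carbon ortho to a chloro group, and (4-hydroxycyclohexyl)amino is accepted there. The swap alters several things together: the linking atom, the ring, the hydrogen-bond donors and the defined stereocentres, and no evidence here shows which of these accounts for the step.

Still open, from the compounds shown here alone, is which part of the new group matters, which a plain cyclohexylamino group or a (4-hydroxycyclohexyl)oxy group would help to separate. Also open, going by these compounds, is whether trifluoromethyl in place of chloro on the other ring gives a similar step when (4-hydroxycyclohexyl)amino is present.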